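A few compounds are considered here, and "the series" means these few. Any claim that something is new, unique, unknown or untested is made for them only; others in the source may bear on it.

The measured compounds:
Compound 1, `CC(C)c1ccc(OC(Cc2ccc(Cl)cc2)C(=O)O)cc1`, gives 10 mg/kg.
Compound 2, `COc1ccc(CC(Oc2ccc(C(C)C)cc2)C(=O)O)cc1`, gives > 50 mg/kg, which is a limit of the assay and not a number.
Compound 3, `COc1ccc(Cc2ccc(OC(C)(Cc3ccc(Cl)cc3)C(=O)O)cc2)cc1`, gives < 10 mg/kg, which is also a limit of the assay and not a number.

All three were tested in a functional assay on the whole organism for inhibition, with Rattus norvegicus as the target; a higher number here means that more compound is needed for the effect, a lower number that less compound is needed. Compound 1 and compound 2 share one core and differ in a single place: chloro in place of methoxy on an aromatic carbon. That change gives an at least 5.0-fold lower number from compound 2 to compound 1 (0.69 log units; beyond the scatter). How the core of compound 3 differs from the core of compound 2 is not broken down here. Compound 4, `CC(Cc1ccc(Cl)cc1)(Oc1ccc(Cc2ccc(Cl)cc2)cc1)C(=O)O`, is made from compound 3 by the same change: chloro in place of methoxy on an aromatic carbon. The place of the change is the same in both pairs, so the step from compound 3 to compound 4 can be set beside the earlier one. Its size is harder to fix because compound 3 sits at the limit of < 10 mg/kg in this assay, at which 1 of the 3 values shown sits. The earlier step also rests on compound 2 sitting at the limit of > 50 mg/kg in this assay, at which 1 of the 3 values shown sits, so it is itself only a bound. Compound 4 is expected to show a step that the limit leaves unreadable from compound 3 to compound 4 in this assay. Compound 4 is estimated at 3 mg/kg in this assay, with a likely range from 1 mg/kg to 10 mg/kg.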

Compound 4, dose for half-maximal effect: > 10 mg/kg
Compound 4 ended at the assay's limit; the forecaster's own chance of this, stated with the estimate: 40%; middle value at least 3.3-fold (0.52 log units) away from the limit.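

In this assay, chloro in place of methoxy on an aromatic carbon does not behave alike on the two cores: the same change on two cores in this assay, an at least 5.0-fold lower number (0.69 log units; beyond the scatter) from compound 2 to compound 1 and a number no lower (the limit leaves the size open) from compound 3 to compound 4, at least 5.0-fold (0.69 log units) apart, beyond the scatter of two such steps. The values for compound 3 and compound 4 are both limits of the assay and not numbers. Within the data shown here, the new step is a number no lower from compound 3 to compound 4 (the limit leaves the size open) and its size cannot be read, only that the number does not fall. This shows that the lower number seen on the core of compound 1 cannot simply be expected on the core of compound 3, but it does not show how large the new step is or what lies behind the difference, and a single pair on each core sets no rule for the series.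

Still open, from the compounds shown here alone, is how a nitrile or an amine in the same place would behave on each of the two cores. Also open, going by these compounds, is the size of the step on the core of compound 3 if both of its ends were given as numbers rather than limits.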